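Swapping (4-ethylphenyl)amino for azetidin-1-yl on a shared core

This account rests on a few compounds, and the source may have more. Where it says the series, first, only, none or still open, it means among the compounds named here.

Measured in a functional assay on MCF7 cells (Homo sapiens) for inhibition, read by sulforhodamine B assay; a higher number here means a weaker inhibitor, a lower number a stronger inhibitor:
- compound 1 `CCc1ccc(NC2=CC(=O)c3c(nc4n3[C@H]3OC[C@@H](O)[C@H]3OC4)C2=O)cc1`: 8990 nM
- compound 2 `O=C1C=C(NC2CCCCC2)C(=O)c2c1nc1n2[C@H]2OC[C@@H](O)[C@H]2OC1`: > 8000 nM (a limit)
- compound 3 `CCOc1ccc(NC2=CC(=O)c3nc4n(c3C2=O)[C@H]2OC[C@@H](O)[C@H]2OC4)cc1`: 1430 nM

Of the two exact numbers in this assay, compound 1 has the higher one, and its gap to compound 3 lies beyond the scatter. The result for compound 2 is only a limit, as the limit of > 8000 nM in this assay, at which 1 of the 3 values shown sits, records.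

Compound 4 `O=C1C(N2CCC2)=CC(=O)c2c1nc1n2[C@H]2OC[C@@H](O)[C@H]2OC1` has not yet been measured. It carries azetidin-1-yl in place of (4-ethylphenyl)amino on a double-bonded ring carbon. Going by the values given here, no measured step makes this exact exchange. The nearest evidence is an at least 5.5-fold lower number from compound 2 to compound 3 (0.74 log units; beyond the scatter), where 4-ethoxyphenyl replaces cyclohexyl on an amine nitrogen and the number falls beyond the scatter. Read in reverse, that step suggests that compound 4, which has no phenyl group, may not improve on compound 1. Yet compound 1 itself, at 8990 nM, keeps a phenyl group and still stands well above compound 3, so this guide is weak. A small rise or no change beyond the scatter therefore seems most likely, and the assay may return only a limit. The expected change is a 1.3-fold higher number from compound 1 to compound 4 (0.13 log units; within the scatter). For compound 4 the estimated value is 12000 nM, with an expected range of 4000 nM to 40000 nM.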

Compound 4, half-maximal inhibitory concentration: > 16000 nM
Compound 4: no number, only a limit (the forecaster's own chance of this, stated with the estimate: 40%); middle value at least 1.3-fold (0.12 log units) from the limit.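

Replacing (4-ethylphenyl)amino with azetidin-1-yl on this double-bonded ring carbon removes the six-membered aromatic ring and the hydrogen-bond donor, and the exchange reads as an at least 1.7-fold higher number from compound 1 to compound 4 (0.25 log units; that floor lies within the scatter). That floor alone does not establish a real loss, but it offers no sign of a gain, and the size of the change in this assay cannot be fixed from a limit. With this result, both compounds shown that carry no phenyl group end in a limit rather than an exact number, and for compound 4 the record is: the limit of > 16000 nM in this assay, at which 1 of the 4 values shown sits.

On these data alone, how far compound 4 truly lies from compound 1 remains open, as a limit sets no upper end to the step. Also open, as far as these compounds go, is whether a piperidine or morpholine on this ring carbon, or an anilino group bearing a carboxylic acid, would return an exact number in this assay.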